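The source may hold more compounds than are shown below. What is called first, only, known or untested is meant among the compounds shown, and "the series" means these compounds.

Measured compounds:
compound 1, `Cc1ccccc1CN1CCc2c(sc(NC(=O)c3ccccc3Cl)c2C(N)=O)C1`, > 50000 nM
compound 2, `NC(=O)c1c(NC(=O)c2ccccc2Cl)sc2c1CCN(C(=S)Nc1ccccc1C(F)(F)F)C2`, 10600 nM

The two measured compounds share a core and differ in the group attached to its ring nitrogen. In a functional assay on HL-60 cells (Homo sapiens) for antiproliferative activity, with a stated time of 24 h (a lower number here means a stronger inhibitor, a higher number a weaker inhibitor), compound 1 returns > 50000 nM, which is a limit of the assay rather than a number. For the measured compounds named here, compound 2 is the one compound with a numerical result in this assay, giving 10600 nM. The other value shown, that of compound 1, is a limit, as noted in the limit of > 50000 nM in this assay, at which 1 of the 2 values shown sits.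

Compound 3, `Cc1ccccc1NC(=S)N1CCc2c(sc(NC(=O)c3ccccc3Cl)c2C(N)=O)C1`, has not yet been measured. It differs from compound 2 in one place: methyl in place of trifluoromethyl on an aromatic carbon. Going by the values given here, no step between measured compounds matches this exchange, so the account can only draw on the value of compound 2.

The author expects compound 3 to stay close to compound 2 in this assay, with a step of a 1.4-fold higher number from compound 2 to compound 3 (0.15 log units; within the scatter) that may be no larger than the scatter, leaning if anything toward weaker inhibition. The estimate for compound 3 is 15000 nM, within a range from 5000 nM to 50000 nM.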

Compound 3, half-maximal inhibitory concentration: 22600 nM
Estimate against measurement, compound 3: 1.5-fold (0.18 log units) below, and the stated range covers the measured number.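

Exchanging trifluoromethyl for methyl, ortho to a large group on the aromatic ring, gives in this assay a 2.1-fold higher number from compound 2 to compound 3 (0.33 log units; beyond the scatter), so this position now has a step that can be read, modest in size but beyond the scatter. Changing the group on the amine nitrogen in the ring gives an at least 2.2-fold lower number from compound 1 to compound 3 (0.34 log units; beyond the scatter), which shows that a group carrying a 2-methylphenyl ring can return a numerical result when it is held on that nitrogen in the form seen in compound 3. That step is a bound rather than a size, since compound 1 stands at a limit of the assay: the limit of > 50000 nM in this assay, at which 1 of the 3 values shown sits.

From the compounds shown here alone, whether a methoxy group, a chlorine atom or plain hydrogen in this place would give a number closer to that of compound 2 or to that of compound 3 remains open, as does the outcome of moving methyl or trifluoromethyl elsewhere on the aromatic ring. Two groups at one position establish no trend, and what lies behind the step cannot be told from these values.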